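The compounds below may be only part of what the source reports. "The series", "measured", "known", "first", "only" and "open" are said of these compounds alone.

Compound 1 `O/N=C(\CCN1CCN(c2ncccn2)CC1)c1ccccc1` gives 39.2 nM in a functional assay on HEK293 cells with D(4) dopamine receptor (Homo sapiens) as the target, read by FLIPR (a higher number here means that more compound is needed for the effect, a lower number that less compound is needed), and compound 2 `CCO/N=C(\CCN1CCN(c2ccccc2C#N)CC1)c1ccccc1` gives 48.7 nM. For compound 3 `CCO/N=C(\CCN1CCN(c2ccc(OC)cc2)CC1)c1ccccc1` this assay reports no number but only a limit, > 10000 nM. The step of an at least 200-fold higher number from compound 2 to compound 3 (2.31 log units; beyond the scatter) is thus large, and compound 3 stands at the limit of > 10000 nM in this assay, at which 1 of the 3 values shown sits, so its true value is not known. Compound 4 `CCO/N=C(\CCN1CCN(c2ncccn2)CC1)c1ccccc1` differs from compound 3 by pyrimidin-2-yl in place of 4-methoxyphenyl on an amine nitrogen in a ring. This change runs opposite to the kind of swap seen in an at least 200-fold higher number from compound 2 to compound 3 (2.31 log units; beyond the scatter), and the pyrimidin-2-yl group is also carried by compound 1 at 39.2 nM. A large step towards a lower number is therefore expected, an at least 200-fold lower number from compound 3 to compound 4 (2.30 log units; beyond the scatter). Compound 4 is expected to give about 50 nM in this assay, within a range from 15 nM to 250 nM.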

Compound 4, half-maximal effective concentration: 615 nM
Compound 4: middle estimate off by 12-fold (1.09 log units), on the low side; the measured number lies above the stated range.
By their numbers in this assay, from the lowest: compounds 1 and 2 (each within the scatter of the next); then compound 4. At a limit, above all of these: compound 3.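

With ethyl on the oxygen throughout, the group on the amine nitrogen in a ring still sets the number: pyrimidin-2-yl gives an at least 16-fold lower number from compound 3 to compound 4 (1.21 log units; beyond the scatter) when it replaces 4-methoxyphenyl and a 13-fold higher number from compound 2 to compound 4 (1.10 log units; beyond the scatter) when it replaces 2-cyanophenyl. Among these compounds, the oxygen proves to be a second sensitive place, with a 16-fold higher number from compound 1 to compound 4 (1.20 log units; beyond the scatter) when ethyl replaces hydrogen, a comparison no earlier pair allowed. The first of these steps is only a minimum because compound 3 has no exact number: the limit of > 10000 nM in this assay, at which 1 of the 4 values shown sits. Still open, going by these compounds, is whether methyl or a longer chain such as propyl on the oxygen would give a number nearer that of hydrogen or of ethyl.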